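Hydroxypyridinyl amide in place of methoxyphenyl amide

The compounds below may be only part of what the source reports. "The series", "measured", "known", "first", "only" and "open" are said of these compounds alone.

Measured so far:
compound 1 `COc1cccc(C(=O)Nc2ccc(Cl)cc2CN2C(=O)c3ccccc3C2=O)c1`: 1500 nM
compound 2 `O=C(/C=C/c1cc(Cl)ccc1NC(=O)c1ccccn1)c1ccccc1`: 1700 nM
compound 3 `COc1ccc2c(c1OC)C(=O)N(Cc1cc(Br)ccc1NC(=O)c1ccccn1)C2=O`: limit only, see below

In an assay on CHO cells for positive allosteric modulation of metabotropic glutamate receptor 5 (Homo sapiens), read by FLIPR (a higher number here means that more compound is needed for the effect, a lower number that less compound is needed), compound 1 gives 1500 nM, the lowest of the two numbers shown; compound 2 gives 1700 nM, which lies within the scatter of compound 1. For compound 3 the result is a limit of this assay, > 100000 nM, not a number (the limit of > 100000 nM in this assay, at which 1 of the 3 values shown sits).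

Compound 4 `O=C(Nc1ccc(Cl)cc1CN1C(=O)c2ccccc2C1=O)c1ncccc1O` keeps the core of compound 1 and differs in one place: 3-hydroxypyridin-2-yl in place of 3-methoxyphenyl on a carbonyl carbon. Among the measured compounds shown here, no measured step carries this change, so nothing beyond the scatter is expected in either direction. Compound 4 is estimated at 1200 nM (range 400 nM to 4000 nM), an expected step of a 1.3-fold lower number from compound 1 to compound 4 (0.10 log units; within the scatter).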

Compound 4, half-maximal effective concentration: 260 nM
For compound 4 the middle estimate is 4.6-fold (0.66 log units) above the measured one, and the stated range ends above it.
By their numbers in this assay, from the lowest: compound 4; then compounds 1 and 2 (each within the scatter of the next). At a limit, above all of these: compound 3.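

Among the compounds shown here, on the core of compound 1, the group on the carbonyl carbon is the first place where a single change moves the number beyond the scatter in this assay: the step is a 5.8-fold lower number from compound 1 to compound 4 (0.76 log units; beyond the scatter), classed as modest. The change replaces the ring and its substituent together, so the step belongs to the pair and not to either part alone. Nothing at hand bears on the cause of this step.

3-Hydroxyphenyl or 3-methoxypyridin-2-yl on the same carbonyl carbon would separate the two parts. From the compounds shown here alone, how an amine in place of the hydroxy group would read remains open.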